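Compound 4: 4-iodophenyl in place of 3-bromophenyl

The compounds below may be only part of what the source reports. "The series", "measured", "known", "first", "only" and "open" are said of these compounds alone.

In an ADME assay on L929 cells (Mus musculus) for cytotoxicity, read by resazurin assay, with a stated time of 96 h (a lower number here means that less compound is tolerated, a higher number that more compound is tolerated), compound 3 `NC(=S)N/N=C(\COc1cccc(Br)c1)c1ccc(Br)cc1` gives > 180000 nM as a limit of the assay and not as a number. Compound 1 `COc1ccc(OC/C(=N\NC(N)=S)c2ccc(Br)cc2)cc1` gives 102000 nM and compound 2 `NC(=S)N/N=C(\COc1ccc(F)cc1)c1ccc(Br)cc1` gives 52300 nM in this assay as well. Compound 4 `NC(=S)N/N=C(\COc1ccc(I)cc1)c1ccc(Br)cc1` carries 4-iodophenyl in place of 3-bromophenyl on an oxygen on a saturated carbon. Within the data shown here, two measured steps bear on this change. Fluoro in place of methoxy gave a 2.0-fold lower number from compound 1 to compound 2 (0.29 log units; within the scatter) and 3-bromophenyl in place of 4-fluorophenyl gave an at least 3.4-fold higher number from compound 2 to compound 3 (0.53 log units; beyond the scatter) in turn. The 4-iodophenyl of compound 4 is named like the 4-fluorophenyl of compound 2, so part of an at least 3.4-fold higher number from compound 2 to compound 3 (0.53 log units; beyond the scatter) is expected to reverse. The expected change is an at least 2.2-fold lower number from compound 3 to compound 4 (0.35 log units; beyond the scatter) toward lower numbers. Compound 4 is estimated at 80000 nM with an expected range from 30000 nM to 180000 nM at its upper end.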

Compound 4, half-maximal cytotoxic concentration: < 20400 nM
Compound 4: only a limit was reported; the forecaster's own chance of this, stated with the estimate: 20%; middle value at least 3.9-fold (0.59 log units) from the limit.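

On this oxygen, 4-iodophenyl gives an at least 8.8-fold lower number from compound 3 to compound 4 (0.94 log units; beyond the scatter) in this assay, so the group at this place can move the number down as well as up. Iodo in place of fluoro gives an at least 2.5-fold lower number from compound 2 to compound 4 (0.40 log units; beyond the scatter) and iodo in place of methoxy gives an at least 5.0-fold lower number from compound 1 to compound 4 (0.69 log units; beyond the scatter), which leaves compound 4 with the lowest number of the four. The value of compound 4 is a limit of the assay, so these steps give only a minimum size: the limit of < 20400 nM in this assay, at which 1 of the 4 values shown sits.

From the compounds shown here alone, it remains open whether the fall follows the iodo itself or its place on the ring. Going by these compounds, how an amine or a carboxylic acid on that ring would read also remains open.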